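Nitro to Amino on a Shared Anilide Carboxamide Scaffold

The compounds below may be only part of what the source reports. "The series", "measured", "known", "first", "only" and "open" are said of these compounds alone.

Measured compounds:
compound 1, `Cc1ccc(NC(=O)c2cccc(C(F)(F)F)c2)cc1NC(=O)c1cnc(Nc2ccc(C)c([N+](=O)[O-])c2)nc1N(C)C`: > 10000 nM (a limit)
compound 2, `Cc1ccc(Nc2ncc(C(=O)Nc3cc(NC(=O)c4cccc(C(F)(F)F)c4)ccc3C)c(N(C)C)n2)cc1N`: > 10000 nM (a limit)
compound 3, `CNc1nc(Nc2ccc(C)c([N+](=O)[O-])c2)ncc1C(=O)Nc1cc(NC(=O)c2ccccc2OC)ccc1C`: > 10000 nM (a limit)

In an ADME assay on BaF3 cells (Mus musculus) for antiproliferative activity, read by CellTiter-Glo and CCK-8 assay, with a stated time of 72 h (on this read-out lower numbers stand for stronger inhibition of growth and higher numbers for weaker inhibition of growth), compound 1 gives > 10000 nM, which is a limit of the assay and not a number. Compound 2 differs from compound 1 only by amino in place of nitro on an aromatic carbon. In this assay compound 2 gives > 10000 nM, again a limit. The step that the two limits leave unreadable from compound 1 to compound 2 cannot be read because of the limit of > 10000 nM in this assay, at which 3 of the 3 values shown sit.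

Compound 3 carries another core; how its core differs from that of compound 1 is not broken down here. In this assay compound 3 gives > 10000 nM, once more a limit. Compound 4, `CNc1nc(Nc2ccc(C)c(N)c2)ncc1C(=O)Nc1cc(NC(=O)c2ccccc2OC)ccc1C`, differs from compound 3 by amino in place of nitro on an aromatic carbon, the same change, at the same kind of place, as that from compound 1 to compound 2.

Because (the limit of > 10000 nM in this assay, at which 3 of the 3 values shown sit), the step expected in this assay is a step that the limit leaves unreadable from compound 3 to compound 4. Compound 4 is accordingly estimated at 20000 nM, expected between 4000 nM and 100000 nM, and most probably reported only as a limit again.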

Compound 4, concentration for 50% growth inhibition: > 10000 nM
Compound 4 was reported as a limit (the forecaster's own chance of this, stated with the estimate: 85%); the middle value lies beyond the limit too.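

In this assay compound 4 gives > 10000 nM, again a limit and not a number. The step from compound 3 to compound 4 therefore cannot be read, because both values are limits: the limit of > 10000 nM in this assay, at which 4 of the 4 values shown sit.

The compounds shown leave open whether amino in place of nitro changes growth inhibition at all in either pair.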